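Removing a Chloro Group from the Benzyl Arm

The compounds below may be only part of what the source reports. "The series", "measured", "known", "first", "only" and "open" are said of these compounds alone.

Compound 1 `O[C@H]1CCCC[C@@H]1Nc1nc(-c2ccccc2)nc2c1nnn2Cc1ccccc1`: 10300000 nM
Compound 2 `OCCNc1nc(-c2ccccc2)nc2c1nnn2Cc1ccccc1`: 38000000 nM
Compound 3 `Clc1ccccc1Cn1nnc2c(NC3CCC3)nc(-c3ccccc3)nc21`: 24000000 nM

Of the compounds shown here, three sharing one core have been measured in an assay on isolated protein for binding affinity to adenosine receptor A1 (Bos taurus); a lower number here means a stronger inhibitor, a higher number a weaker inhibitor. Compound 3 gives the second highest number of the three; its nearest neighbour is compound 2, within the scatter, while compound 1 lies beyond the scatter at a lower number. Within the data shown here, the only single-point step measured so far, a 3.7-fold higher number from compound 1 to compound 2 (0.57 log units; beyond the scatter), concerns the group on the ring nitrogen, not the benzyl arm. Compound 4 `c1ccc(Cn2nnc3c(NC4CCC4)nc(-c4ccccc4)nc32)cc1` differs from compound 3 by hydrogen in place of chloro on an aromatic carbon. Among the measured compounds shown here, no measured step touches this position, so the data give no direction for it. The expected step is therefore a 1.2-fold lower number from compound 3 to compound 4 (0.08 log units; within the scatter), nothing beyond the scatter. Compound 4 is expected to give 20000000 nM in this assay, within a range of 8000000 nM to 50000000 nM.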

Compound 4, inhibition constant: 5000000 nM
Estimate against measurement, compound 4: 4.0-fold (0.60 log units) above; the whole stated range lies above it.
By their numbers in this assay, from the lowest: compound 4; then compound 1; then compounds 3 and 2 (each within the scatter of the next).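

In this assay, hydrogen in place of chloro on this aromatic carbon gives a clear change (a 4.8-fold lower number from compound 3 to compound 4 (0.68 log units; beyond the scatter)), so this position does affect the number. With the unsubstituted benzyl arm, cyclobutyl on the nitrogen also beats both hydroxylated groups (a 7.6-fold lower number from compound 2 to compound 4 (0.88 log units; beyond the scatter); a 2.1-fold lower number from compound 1 to compound 4 (0.31 log units; beyond the scatter)), which makes compound 4 the strongest of the four. No measurement shown here explains these changes. Still open, on these data alone, is whether a fluoro or methoxy group on that carbon would give a number closer to compound 3 or compound 4, and whether removing chloro has the same effect with 2-hydroxyethyl on the nitrogen.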